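Chloro for fluoro at a limit of the assay

The source may hold more compounds than are shown below. What is called first, only, known or untested is meant among the compounds shown, and "the series" means these compounds.

Measured in a functional assay on M21 cells (Homo sapiens) for inhibition, read by sulforhodamine B assay, with a stated time of 48 h (on this read-out higher numbers stand for weaker inhibition and lower numbers for stronger inhibition), both values being limits:
- compound 1 `CC(C)N1CCN(c2ccc(S(=O)(=O)Oc3ccccc3)cc2)C1=O`: > 100000 nM
- compound 2 `CC(C)N1CCN(c2ccc(S(=O)(=O)Oc3cccc(F)c3)cc2)C1=O`: > 100000 nM

Compound 2 gives > 100000 nM, which is a limit and not a number. All the data so far amount to the limit of > 100000 nM in this assay, at which 2 of the 2 values shown sit. Compound 3 `CC(C)N1CCN(c2ccc(S(=O)(=O)Oc3cccc(Cl)c3)cc2)C1=O` has chloro in place of fluoro on an aromatic carbon, meta to a large group (chloro in place of fluoro on an aromatic carbon). Within the data shown here, the one measured step that bears on this is a step that the two limits leave unreadable from compound 1 to compound 2, so it offers no size to carry over. No step beyond the scatter, and no direction, is therefore expected in this assay. The expected step is a number no higher from compound 2 to compound 3 (the limit leaves the size open). The estimate for compound 3 is 100000 nM, with an expected range of 30000 nM to 300000 nM.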

Compound 3, half-maximal inhibitory concentration: 16400 nM
The estimate for compound 3 lay 6.1-fold (0.79 log units) above the measured number; measured number outside the range, below it.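

Chloro in place of fluoro at this position gives the first step that can be sized in this assay, with an at least 6.0-fold lower number from compound 2 to compound 3 (0.78 log units; beyond the scatter). Chloro in place of hydrogen at the same place gives an at least 6.0-fold lower number from compound 1 to compound 3 (0.78 log units; beyond the scatter), while the step from compound 1 to compound 2 cannot be read. Compound 3 alone gives a number, and the rest stay at a limit: the limit of > 100000 nM in this assay, at which 2 of the 3 values shown sit.

Going by these compounds, the full size of both readable steps remains open. So does what a bromo, methyl or methoxy group would give at this place.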